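Octylsulfanyl in place of cyclopentylamino in a cytotoxicity series

This account rests on a few compounds, and the source may have more. Where it says the series, first, only, none or still open, it means among the compounds named here.

In an ADME assay on CCRF-HSB-2 cells (Homo sapiens) for cytotoxicity, with a stated time of 7 days (on this read-out lower numbers stand for higher toxicity in this test and higher numbers for lower toxicity in this test), compound 3 (`Nc1nc(NC2CCCC2)c2ncn(/C=C3/CC3(CO)CO)c2n1`) gives > 20000 nM, which is a limit and not a number. Compound 1 (`CNc1nc(N)nc2c1ncn2/C=C1/CC1(CO)CO`) gives > 20000 nM, and that is also a limit. Compound 2 (`CC(C)CSc1nc(N)nc2c1ncn2/C=C1/CC1(CO)CO`) alone has a number in this assay, at 60000 nM. Among the compounds with values here, the series so far is thus marked by the limit of > 20000 nM in this assay, at which 2 of the 3 values shown sit.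

The next structure is compound 4 (`CCCCCCCCSc1nc(N)nc2c1ncn2/C=C1/CC1(CO)CO`), and the change is octylsulfanyl in place of cyclopentylamino on an aromatic carbon. It puts a longer sulfur-linked chain on the aromatic carbon that carries isobutylsulfanyl in compound 2.

The measured steps give no size to carry forward. That holds for a step that the limit leaves unreadable from compound 1 to compound 2, for a step that the limit leaves unreadable from compound 2 to compound 3 and for a step that the two limits leave unreadable from compound 1 to compound 3. The nearest guide is therefore a single value: compound 2, the other sulfanyl member, gives 60000 nM. Within the data shown here, with only that number, no clear step in either direction is expected, and a reported limit is about as likely as a number. The expected step is a step that the limit leaves unreadable from compound 3 to compound 4, an estimate of low confidence. Compound 4 is expected at about 25000 nM, with an estimated range of 7000 nM to 80000 nM.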

Compound 4, half-maximal cytotoxic concentration: 60000 nM
The estimate for compound 4 lay 2.4-fold (0.38 log units) below the measured number, within the range that was stated.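

Within the data shown here, at this aromatic carbon, heptyl in place of isopropyl on a saturated chain carbon bound to a sulfur gives no change at the digits printed from compound 2 to compound 4 (within the scatter), the first step that can be read. In this assay, the branched isobutylsulfanyl of compound 2 and the unbranched octylsulfanyl of compound 4 therefore cannot be told apart, which holds for these two sulfanyl members only. The steps to compound 4 from compound 1 and from compound 3 cannot be read, because each of those compounds has only a limit and no number: the limit of > 20000 nM in this assay, at which 2 of the 4 values shown sit.

The compounds shown leave open whether the sulfur link gives a different read-out from the nitrogen link at this carbon, since no amino member here carries a number to set against the sulfanyl pair. They also leave open whether a shorter chain such as methylsulfanyl, a benzylsulfanyl group or a sulfur-linked chain ending in a carboxylic acid would stand apart from the two sulfanyl members.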